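The source may hold more compounds than are shown below. What is called first, only, known or untested is meant among the compounds shown, and "the series" means these compounds.

Compound 3 `COC(=O)/C=C/c1cccc(N(Cc2ccc(/C=C/c3cccc(Cl)c3)cc2)C(=O)C2CCCCC2)c1` gives 165 nM in an assay on isolated protein with Bile acid receptor (Homo sapiens) as the target (on this read-out higher numbers stand for an effect only at larger amounts of compound and lower numbers for an effect already at smaller amounts), and stands second highest of the three numbers in hand. Its nearest neighbour is compound 2 `COC(=O)/C=C/c1cccc(N(Cc2ccc(-c3cccc(OC(F)(F)F)c3)cc2)C(=O)C(C)C)c1`, which gives 247 nM in this assay, and the furthest is compound 1 `COC(=O)/C=C/c1cccc(N(Cc2ccc(/C=C/c3cccc(F)c3)cc2)C(=O)C2CCCCC2)c1`, which gives 86 nM in this assay; both gaps lie within the scatter, so no order among the three is claimed. For the measured compounds named here, the one step between neighbours that differ in a single place is a 1.9-fold higher number from compound 1 to compound 3 (0.28 log units; within the scatter), also within the scatter.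

Compound 4 `COC(=O)/C=C/c1cccc(N(Cc2ccc(-c3cccc(OC(F)(F)F)c3)cc2)C(=O)C2CCCCC2)c1` differs from compound 3 by 3-(trifluoromethoxy)phenyl in place of 2-(3-chlorophenyl)ethenyl on an aromatic carbon. Going by the values given here, no measured pair isolates this exchange. Compound 2 already carries the 3-(trifluoromethoxy)phenyl group, but with a different amide substituent, so the comparison of compound 3 and compound 2 is confounded; all that can be said is that the two values lie within the scatter of each other. Neither the step from compound 1 to compound 3 nor any other shown step points to a shift beyond the scatter for this kind of replacement on the present core.

In this assay the expected step is a 1.2-fold higher number from compound 3 to compound 4 (0.08 log units; within the scatter), that is no change beyond the scatter. Compound 4 is therefore estimated at 200 nM, with a range from 80 nM to 500 nM.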

Compound 4, half-maximal effective concentration: 420 nM
Estimate against measurement, compound 4: 2.1-fold (0.32 log units) below, within the range that was stated.
By their numbers in this assay, from the lowest: compounds 1, 3, 2 and 4 (each within the scatter of the next, the first and the last beyond it).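

For the compounds shown here, with the cyclohexyl amide held constant, the exchange at this aromatic carbon, para to a large group, is the first to give steps beyond the scatter in this assay: 3-(trifluoromethoxy)phenyl in place of 2-(3-chlorophenyl)ethenyl gives a 2.5-fold higher number from compound 3 to compound 4 (0.41 log units; beyond the scatter) and in place of 2-(3-fluorophenyl)ethenyl gives a 4.9-fold higher number from compound 1 to compound 4 (0.69 log units; beyond the scatter) and both steps are modest. Going by these compounds alone, the amide position behaves differently in the one pair that isolates it, since cyclohexyl in place of isopropyl on the carbonyl carbon gives a 1.7-fold higher number from compound 2 to compound 4 (0.23 log units; within the scatter) and so shows no change beyond the scatter between these two compounds carrying 3-(trifluoromethoxy)phenyl. No measurement at hand bears on the origin of these steps.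

The exchange alters the link and the ring substituent at once, and separating them would take a 3-chlorophenyl group attached directly at this aromatic carbon, or a 2-(3-(trifluoromethoxy)phenyl)ethenyl group on the same cyclohexyl amide. Also open, on these data alone, is how this position responds to other kinds of group, such as a carboxylic acid or an amine on the terminal aromatic ring.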